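A few compounds are considered here, and "the series" means these few. Any claim that something is new, unique, unknown or untested is made for them only; others in the source may bear on it.

In a functional assay on HL-60 cells (Homo sapiens) for antiproliferative activity, read by MTT assay, with a stated time of 72 h (on this read-out lower numbers stand for stronger inhibition and higher numbers for weaker inhibition), compound 1 `CNc1nc(-c2cc(OC)c(OC)c(OC)c2)c(-c2ccc3ccccc3c2)s1` gives 143 nM. Within the data shown here, this is the middle of the three numbers so far: compound 2 `CNc1nc(-c2cc(OC)c(OC)c(OC)c2)c(-c2ccc(C(F)(F)F)cc2)s1` sits higher at 3170 nM, and compound 3 `CCOc1ccc(-c2sc(NC)nc2-c2cc(OC)c(OC)c(OC)c2)cc1` sits lower at 1.8 nM. Compound 4 `COc1cc(-c2nc(N(C)C)sc2-c2ccc3ccccc3c2)cc(OC)c1OC` differs from compound 1 in one place: methyl in place of hydrogen on a nitrogen on an aromatic ring. In other words, methylamino becomes dimethylamino.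

Among the measured compounds shown here, the only measured single-place step is a 1800-fold lower number from compound 2 to compound 3 (3.25 log units; beyond the scatter). It is large, but it puts ethoxy in place of trifluoromethyl on an aromatic carbon and leaves the nitrogen untouched. For the measured compounds named here, it therefore says nothing about direction here, and shows only that one change can move this read-out a long way. Going by the values given here, all three measured compounds carry methylamino, so no measured pair tests the new methyl. A moderate move towards weaker inhibition is expected as a cautious judgement, and a step within the scatter remains possible. The expected step is a 4.9-fold higher number from compound 1 to compound 4 (0.69 log units; beyond the scatter). For compound 4 the estimated value is 700 nM, with an expected range from 140 nM to 4000 nM.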

Compound 4, half-maximal inhibitory concentration: 2570 nM
Compound 4: the middle estimate sits 3.7-fold (0.56 log units) below what was measured; measured number inside the range.
By their numbers in this assay, from the lowest: compound 3; then compound 1; then compounds 4 and 2 (each within the scatter of the next).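

In this assay, going from methylamino to dimethylamino gives an 18-fold higher number from compound 1 to compound 4 (1.25 log units; beyond the scatter) and so weakens inhibition. Among these compounds, all the earlier compounds carried methylamino, so this is the first sign that the read-out is sensitive to what sits on this nitrogen: one added carbon is enough for a large move. The change adds a methyl and also removes the last hydrogen on that nitrogen, and no information here bears on why the number rises or separates these two parts of the change.

Still open, as far as these compounds go, is how the read-out responds to a plain amino group, with no methyl on the nitrogen, or to a longer chain such as ethylamino. Also open, from the compounds shown here alone, is whether dimethylamino would cost as much alongside the ethoxy group of compound 3 as it does in compound 1.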